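Ester series: benzyl ether variant of compound 2

The source may report more compounds than this note shows. Statements on the series, on what has been measured and on what is new or still open speak of the compounds shown alone.

Measured compounds:
compound 1 `CCOC(=O)c1c(-c2ccccc2)nn(-c2ccccc2)c1Cn1cnc2ccccc21`: 35 ug/mL
compound 2 `CCOC(=O)c1c(-c2ccccc2)nn(-c2ccccc2)c1COc1ccc(C=O)cc1`: 60 ug/mL

In an assay for inhibition of Alpha amylase (Homo sapiens), with a stated time of 30 min (a higher number here means a weaker inhibitor, a lower number a stronger inhibitor), compound 2 gives 60 ug/mL, the higher of the two numbers, and the step of a 1.7-fold higher number from compound 1 to compound 2 (0.23 log units; within the scatter) lies within the scatter. Compound 3 `CCOC(=O)c1c(-c2ccccc2)nn(-c2ccccc2)c1COCc1ccccc1` differs from compound 2 by benzyl in place of 4-formylphenyl on an oxygen on a saturated carbon. Going by the values given here, the single step known changes the group on a saturated chain carbon bound to an aromatic carbon and was small; no step alters the aryl on the ether oxygen, so nothing beyond the scatter is expected here. Compound 3 is expected at 60 ug/mL (range 25 ug/mL to 130 ug/mL), meaning a step of no change at the digits printed from compound 2 to compound 3 (within the scatter).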

Compound 3, half-maximal inhibitory concentration: 45 ug/mL
Compound 3: middle estimate off by 1.3-fold (0.12 log units), on the high side, and the stated range covers the measured number.
By their numbers in this assay, from the lowest: compounds 1, 3 and 2 (each within the scatter of the next).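

In this assay, benzyl in place of 4-formylphenyl on an oxygen on a saturated carbon gives a 1.3-fold lower number from compound 2 to compound 3 (0.12 log units; within the scatter) and so the aryl on the ether oxygen, with its formyl group, can change without leaving the scatter. Benzyloxy in place of 1H-benzimidazol-1-yl gives a 1.3-fold higher number from compound 1 to compound 3 (0.11 log units; within the scatter) and so all three groups at this saturated chain carbon read alike. No independent evidence bears on this result.

Open, going by these compounds, is whether a longer chain in place of benzyl, or an amine or a carboxylic acid on the aromatic ring, would move the number beyond the scatter.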